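Swapping the Aryl Group on the Ring Nitrogen

A few compounds are considered here, and "the series" means these few. Any claim that something is new, unique, unknown or untested is made for them only; others in the source may bear on it.

Of the compounds shown here, three built on a shared core have been measured in a functional assay on SW 1116 cells (Homo sapiens) for antiproliferative activity, read by MTT assay, with a stated time of 48 h; a lower number here means a stronger inhibitor, a higher number a weaker inhibitor. Compound 1 `S=c1oc(-c2ccc3c(c2)OCCO3)nn1CN1CCN(C(c2ccccc2)c2ccccc2)CC1` gives 21600 nM, compound 2 `S=c1oc(-c2ccc3c(c2)OCCO3)nn1CN1CCN(c2cccc(Cl)c2Cl)CC1` gives 37100 nM, and compound 3 `COc1ccccc1N1CCN(Cn2nc(-c3ccc4c(c3)OCCO4)oc2=S)CC1` gives 16900 nM. Compound 3 holds the lowest of the three numbers, but its gap to compound 1 lies within the scatter, so no order between those two can be read; only a 2.2-fold lower number from compound 2 to compound 3 (0.34 log units; beyond the scatter) is a step that reaches beyond the scatter, and it is a modest one.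

Compound 4 `O=[N+]([O-])c1ccc(N2CCN(Cn3nc(-c4ccc5c(c4)OCCO5)oc3=S)CC2)cc1` has not yet been measured. It differs from compound 3 in one place: 4-nitrophenyl in place of 2-methoxyphenyl on an amine nitrogen in a ring. Within the data shown here, the one measured step that bears on such a change is a 2.2-fold lower number from compound 2 to compound 3 (0.34 log units; beyond the scatter), which was modest, and compounds 1 and 3 show that a further variation at the same amine nitrogen in a ring left the two numbers within the scatter of each other. A further aryl swap at that position is therefore expected to shift this assay little, if at all beyond the scatter. For compound 4 the expected value in this assay is 20000 nM, within a range from 8000 nM to 50000 nM. The step this estimate implies, a 1.2-fold higher number from compound 3 to compound 4 (0.07 log units; within the scatter), is expected to remain small.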

Compound 4, half-maximal inhibitory concentration: > 50000 nM
Compound 4 ended at the assay's limit (the forecaster's own chance of this, stated with the estimate: 10%); middle value at least 2.5-fold (0.39 log units) from the limit.
By their numbers in this assay, from the lowest: compounds 3, 1 and 2 (each within the scatter of the next, the first and the last beyond it). At a limit, above all of these: compound 4.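

For compound 4 the reading in this assay is a limit of the assay and not a number: the limit of > 50000 nM in this assay, at which 1 of the 4 values shown sits. Even so, 4-nitrophenyl in place of 2-methoxyphenyl gives an at least 2.9-fold higher number from compound 3 to compound 4 (0.47 log units; beyond the scatter), which shows that a single aryl swap on this amine nitrogen in a ring can raise the number beyond the scatter, whereas the earlier compounds had shown only one modest step, in the downward direction from compound 2 to compound 3. As far as these compounds go, the comparison with the dichlorinated analogue is less informative, with an at least 1.3-fold higher number from compound 2 to compound 4 (0.12 log units; that floor lies within the scatter), so 4-nitrophenyl and 2,3-dichlorophenyl cannot be put in order on these data, and the full size of both steps stays unknown.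

Whether the higher number goes with the nitro group itself or with its place on the phenyl ring remains open, as the compounds shown change both together. A 2-nitrophenyl group and a 4-methoxyphenyl group on the same nitrogen would pull these two apart, and a 4-aminophenyl group would show whether the nitro group's nitrogen alone is enough to give such a reading.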